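Adding a second fluoro to compound 3

This account rests on a few compounds, and the source may have more. Where it says the series, first, only, none or still open, it means among the compounds named here.

Measured in a functional assay on NCI-H460 cells (Homo sapiens) for antiproliferative activity, with a stated time of 72 h; a higher number here means a weaker inhibitor, a lower number a stronger inhibitor:

- compound 1 `CCCCC#Cc1cc([C@@H]2O[C@H](CO)[C@@H](O)[C@H]2O)n2ncnc(N)c12` gives 1700 nM
- compound 2 `Nc1ncnn2c([C@@H]3O[C@H](CO)[C@@H](O)[C@H]3O)cc(-c3ccccc3)c12` gives > 100000 nM (a limit of the assay, not a number)
- compound 3 `Nc1ncnn2c([C@@H]3O[C@H](CO)[C@@H](O)[C@H]3O)cc(-c3ccc(F)cc3)c12` gives 55500 nM

Of the two values that are true numbers, compound 3 holds the higher one, and the gap to its nearest neighbour is large: a 33-fold higher number from compound 1 to compound 3 (1.51 log units; beyond the scatter). Compound 4 `Nc1ncnn2c([C@@H]3O[C@H](CO)[C@@H](O)[C@H]3O)cc(-c3ccc(F)cc3F)c12` has not yet been measured. It differs from compound 3 by fluoro in place of hydrogen on an aromatic carbon. This is fluoro in place of hydrogen on an aromatic carbon, ortho to a large group and meta to a fluoro group, and it turns 4-fluorophenyl into 2,4-difluorophenyl.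

The two large steps, an at least 58-fold higher number from compound 1 to compound 2 (1.76 log units; beyond the scatter) and a 33-fold higher number from compound 1 to compound 3 (1.51 log units; beyond the scatter), replace hex-1-yn-1-yl and so say little about this change. Within the data shown here, the only measured step of the same kind is an at least 1.8-fold lower number from compound 2 to compound 3 (0.25 log units; that floor lies within the scatter), and it gives no sign of a real shift. No step beyond the scatter is therefore expected in this assay, and the expected step is a 1.0-fold lower number from compound 3 to compound 4 (0.00 log units; within the scatter). For compound 4 the estimated value is 55000 nM, with an expected range from 20000 nM to 100000 nM.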

Compound 4, half-maximal inhibitory concentration: 93300 nM
For compound 4 the middle estimate is 1.7-fold (0.23 log units) below the measured one, and the stated range covers the measured number.
By their numbers in this assay, from the lowest: compound 1; then compounds 3 and 4 (each within the scatter of the next). At a limit, above all of these: compound 2.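

In this assay, turning 4-fluorophenyl into 2,4-difluorophenyl gives a step that stays within the scatter: a 1.7-fold higher number from compound 3 to compound 4 (0.23 log units; within the scatter). This is the first fluoro step shown with a true number at both ends, and it indicates that a fluoro on this aromatic carbon, ortho to a large group and meta to a fluoro group, does not measurably shift the antiproliferative read-out, while the large gap to the hex-1-yn-1-yl compound remains, with a 55-fold higher number from compound 1 to compound 4 (1.74 log units; beyond the scatter). One further step starts from a limit of the assay and gives only a floor: an at least 1.0-fold lower number from compound 2 to compound 4 (0.03 log units; that floor lies within the scatter). Compound 2 stands at that limit, which is not a number: the limit of > 100000 nM in this assay, at which 1 of the 4 values shown sits.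

The phenyl rings shown carry only fluoro, so it stays open whether an amine, a methoxy group or a carboxylic acid on that ring would narrow the gap to compound 1. Also open, going by these compounds, is how a shorter or longer alkyne chain in place of hex-1-yn-1-yl would compare with compound 1, and whether the fluoro step would look the same in another cell line.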